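From Hydroxyphenyl to Pyridinyl: An Expected Loss in Binding

The source may report more compounds than this note shows. Statements on the series, on what has been measured and on what is new or still open speak of the compounds shown alone.

Measured compounds:
- compound 1, `CCCn1c(=O)c2nc(-c3ccc(O)cc3)[nH]c2n(C)c1=O`, 1.28 nM
- compound 2, `CCCn1c(=O)n(C)c(=O)c2[nH]c(-c3ccc(O)cc3)nc21`, 2.54 nM
- compound 3, `CCCn1c(=O)n(C)c(=O)c2[nH]c(-c3ccc(C#N)cc3)nc21`, 13.9 nM

These three compounds share one core and differ in the group carried on the five-membered ring. In an assay on Cortex for displacement of a labelled ligand from adenosine receptor A1 (Rattus norvegicus) (on this read-out higher numbers stand for weaker inhibition and lower numbers for stronger inhibition), compound 2 gives 2.54 nM, the second highest of the three numbers. Its nearest neighbour is compound 1, whose value is within the scatter of compound 2, so the two cannot be told apart. Its furthest neighbour is compound 3, which lies beyond the scatter.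

Compound 4, `CCCn1c(=O)n(C)c(=O)c2[nH]c(-c3ccncc3)nc21`, has not yet been measured. It differs from compound 2 in one place: pyridin-4-yl in place of 4-hydroxyphenyl on an aromatic carbon. The closest measured step is the exchange of the hydroxy group for a nitrile on the same aromatic carbon, a 5.5-fold higher number from compound 2 to compound 3 (0.74 log units; beyond the scatter). That step removed the hydrogen-bond donor and weakened binding modestly. The change to compound 4 also removes the donor while keeping one acceptor, so a step of similar size in the same direction is expected, a 5.9-fold higher number from compound 2 to compound 4 (0.77 log units; beyond the scatter). Compound 4 is therefore expected to give about 15 nM in this assay, with a range from 4 nM to 60 nM.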

Compound 4, inhibition constant: 21.8 nM
Compound 4: middle estimate off by 1.5-fold (0.16 log units), on the low side; low and high end bracket the measured number.
By their numbers in this assay, from the lowest: compounds 1 and 2 (each within the scatter of the next); then compounds 3 and 4 (each within the scatter of the next).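

In this assay the change to pyridin-4-yl on this aromatic carbon, which lies between two ring nitrogen atoms, gives weaker binding than 4-hydroxyphenyl (an 8.6-fold higher number from compound 2 to compound 4 (0.93 log units; beyond the scatter)), so a second, different replacement of that group now also raises the number beyond the scatter. Compound 3 and compound 4 lie within the scatter of each other, which means that a nitrile on the phenyl ring and a nitrogen atom within the ring cannot be told apart in this assay, even though the two changes differ in kind. Both new groups lack the hydrogen-bond donor of 4-hydroxyphenyl, but pyridin-4-yl also changes the ring itself, and no measurement here explains the rise in the number.

The compounds shown therefore cannot separate the loss of the hydroxy hydrogen from the other differences between these groups. From the compounds shown here alone, a phenyl ring carrying a methoxy group, an amine or a carboxylic acid in place of the hydroxy group would test this position further, and how any of these would read remains open.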